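Saturating the Indene Ring: An Estimate for Compound 4

A few compounds are considered here, and "the series" means these few. Any claim that something is new, unique, unknown or untested is made for them only; others in the source may bear on it.

Three compounds share a piperazine core linked to a benzodioxane. Compound 1 `Clc1cccc2c1CC2CCCN1CCN(c2cccc3c2OCCO3)CC1` gives 1100 nM in an assay on isolated protein for binding affinity to 5-hydroxytryptamine receptor 1B (Rattus norvegicus) (on this read-out lower numbers stand for stronger inhibition and higher numbers for weaker inhibition), compound 2 `C1=C(CCN2CCN(c3cccc4c3OCCO4)CC2)Cc2ccccc21` gives 933 nM, and compound 3 `c1ccc2c(c1)CCC2CCCN1CCN(c2cccc3c2OCCO3)CC1` gives 204 nM. Compound 2 therefore sits second highest of the three, close to compound 1 and well above compound 3. Compound 4 `c1ccc2c(c1)CCC2CCN1CCN(c2cccc3c2OCCO3)CC1` differs from compound 2 by one change: a group of 9 heavy atoms (9 carbon; one five-membered non-aromatic ring of carbon only, one six-membered aromatic ring of carbon only) in place of a group of 9 heavy atoms (9 carbon; one five-membered non-aromatic ring of carbon only, one six-membered aromatic ring of carbon only), on a saturated chain carbon, two bonds along the chain from an amine nitrogen in a ring. Going by the values given here, the only measured step, a 5.4-fold lower number from compound 1 to compound 3 (0.73 log units; beyond the scatter), swaps a different ring system on a longer chain, so it bears only loosely here. Among the compounds with values here, compound 3 carries the same indanyl group as compound 4, yet on a longer chain, so no single measured step settles the matter. A modest improvement is expected, a 2.1-fold lower number from compound 2 to compound 4 (0.32 log units; beyond the scatter), giving compound 4 an estimated 450 nM with a range from 150 nM to 1300 nM.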

Compound 4, inhibition constant: 417 nM
For compound 4 the middle estimate is 1.1-fold (0.03 log units) above the measured one; measured number inside the range.
By their numbers in this assay, from the lowest: compound 3; then compound 4; then compounds 2 and 1 (each within the scatter of the next).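

In this assay, putting 2,3-dihydro-1H-inden-1-yl in place of the group with a double bond outside aromatic rings gives a 2.2-fold lower number from compound 2 to compound 4 (0.35 log units; beyond the scatter) at this place, on a saturated chain carbon, two bonds along the chain from an amine nitrogen in a ring. Going by these compounds alone, both groups have the same heavy-atom count and ring types, so losing that double bond is the only change, and it is enough to move the number beyond the scatter. Nothing measured here explains the shift.

Open still is whether a hydroxyl group or an amine on the five-membered non-aromatic ring would move the number further, and in which direction.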